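From amino to cyclopropylamino on a fluorinated core

The source may report more compounds than this note shows. Statements on the series, on what has been measured and on what is new or still open speak of the compounds shown alone.

Measured in a functional assay on HCT-116 cells (Homo sapiens) for cytotoxicity, read by sulforhodamine B assay, with a stated time of 72 h; on this read-out higher numbers stand for weaker inhibition and lower numbers for stronger inhibition:
Compound 1 `OCC1=C(F)[C@@H](n2cnc3c(NC4CC4)ncnc32)[C@H](O)[C@@H]1O`: > 100000 nM
Compound 2 `Nc1nc(O)c2ncn([C@@H]3C(F)=C(CO)[C@@H](O)[C@H]3O)c2n1`: > 100000 nM
Compound 3 `Nc1nc(N)c2ncn([C@@H]3C(F)=C(CO)[C@@H](O)[C@H]3O)c2n1`: 21900 nM

For the measured compounds named here, compound 3 holds the only actual number in the set. The other two compounds sit at the limit of > 100000 nM in this assay, at which 2 of the 3 values shown sit. Compound 4 `Nc1nc(NC2CC2)c2ncn([C@@H]3C(F)=C(CO)[C@@H](O)[C@H]3O)c2n1` is made from compound 3 by one change: cyclopropyl in place of hydrogen on a nitrogen on an aromatic ring, which turns amino into cyclopropylamino.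

Going by the values given here, one measured step bears on this: an at least 4.5-fold lower number from compound 2 to compound 3 (0.65 log units; beyond the scatter), with amino in place of hydroxy on an aromatic carbon. The amino group gained in that step is the one now altered, but the step does not give the size of this new change. Compound 1, which also carries cyclopropylamino, stands at > 100000 nM, which is a limit and not a number. Together these suggest weaker inhibition in this assay if anything, though no shift beyond the scatter is firmly expected. The expected change is a 1.6-fold higher number from compound 3 to compound 4 (0.20 log units; within the scatter). For compound 4 the estimated value is 35000 nM, with an expected range from 8000 nM to 100000 nM.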

Compound 4, half-maximal inhibitory concentration: > 100000 nM
Compound 4 was reported as a limit; the forecaster's own chance of this, stated with the estimate: 40%; middle value at least 2.8-fold (0.45 log units) away from the limit.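

Cyclopropyl on the nitrogen gives an at least 4.5-fold higher number from compound 3 to compound 4 (0.65 log units; beyond the scatter) in this assay, so this change on the amino group of compound 3 costs activity rather than leaving it within the scatter. Among the groups shown at this position on the shared core, only the plain amino group of compound 3 gives an actual number, 21900 nM. Hydroxy in compound 2 and cyclopropylamino in compound 4 both end at a limit. The steps from compound 2 and from compound 1 to compound 4 cannot be read, as both ends of each are limits: the limit of > 100000 nM in this assay, at which 3 of the 4 values shown sit.

As far as these compounds go, how far compound 4 lies past its limit stays open, and with it the full size of the step. Also open, from the compounds shown here alone, is whether methyl or a longer chain such as ethyl on this nitrogen would keep a measurable value.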